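Chloro added to a nitrophenyl amide: expected cytotoxicity

This account rests on a few compounds, and the source may have more. Where it says the series, first, only, none or still open, it means among the compounds named here.

Measured so far:
compound 1, `O=C1c2ccccc2C(=O)N1CCOC(=S)N(C(=O)c1cccc([N+](=O)[O-])c1)c1ccc(Cl)cc1`: 18000 nM
compound 2, `O=C1c2ccccc2C(=O)N1CCOC(=S)N(C(=O)c1ccc(Br)cc1)c1ccc(Br)cc1`: 73000 nM
compound 3, `Cc1ccc(N(C(=O)c2ccccc2C)C(=S)OCCN2C(=O)c3ccccc3C2=O)cc1`: > 100000 nM

The three compounds share a core and were tested in an ADME assay on MT4 cells (Homo sapiens) for cytotoxicity, read by MTT assay; a higher number here means that more compound is tolerated, a lower number that less compound is tolerated. Compound 1 gives 18000 nM, the lowest of the two numbers, and compound 2 gives 73000 nM, a gap that lies beyond the scatter. For compound 3 this assay reports only a limit, > 100000 nM, not a number; this is the limit of > 100000 nM in this assay, at which 1 of the 3 values shown sits.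

The unmeasured compound 4, `O=C1c2ccccc2C(=O)N1CCOC(=S)N(C(=O)c1cc([N+](=O)[O-])ccc1Cl)c1ccc(Cl)cc1`, differs from compound 1 in one place: chloro in place of hydrogen on an aromatic carbon. Read one bond further out, the 3-nitrophenyl becomes 2-chloro-5-nitrophenyl, the chloro standing ortho to a large group and para to the nitro group.

Going by the values given here, no pair of measured compounds differing in one place is available, so the step from compound 1 to compound 4 in this assay is judged without a measured precedent. A small step is expected, toward a slightly lower number, but it may well fall within the scatter: the estimated step is a 1.3-fold lower number from compound 1 to compound 4 (0.11 log units; within the scatter). Compound 4 is therefore expected to give about 14000 nM, with a likely range from 5000 nM to 45000 nM.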

Compound 4, half-maximal cytotoxic concentration: 45000 nM
Beside the measured number, compound 4's estimate is 3.2-fold (0.51 log units) below it; low and high end bracket the measured number.
By their numbers in this assay, from the lowest: compound 1; then compounds 4 and 2 (each within the scatter of the next). At a limit, above all of these: compound 3.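

In this assay, going by these compounds alone, the only step between compounds differing in one place reads a 2.5-fold higher number from compound 1 to compound 4 (0.40 log units; beyond the scatter) and gives this series its first direct look at a change on the 3-nitrophenyl. The step is modest but lies beyond the scatter, so at this place, ortho to a large group and para to a nitro group, chloro in place of hydrogen goes with more compound being tolerated, not less, in this one pair. Nothing shown explains the direction of this step, and the single limit among the values, the one for compound 3, does not bear on it.

Going by these compounds, whether the step belongs to chloro itself remains open, since a fluoro, a methyl, a methoxy group or an amine at the same place would be needed to tell that apart from a change common to any group there. Also open, on these data alone, is whether chloro has the same effect on this number in a compound without the nitro group, as a single pair cannot show how far the step carries beyond the 2-chloro-5-nitrophenyl.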